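Swapping 4-methylphenyl for 3,4-difluorophenyl in compound 2

The source may hold more compounds than are shown below. What is called first, only, known or untested is meant among the compounds shown, and "the series" means these compounds.

Among the measured compounds shown here, compound 1 `O=C1Nc2c(ccc(F)c2F)C1(c1ccccc1)c1ccc(O)cc1` gives 7.1 nM in a functional assay on MCF7 cells (Homo sapiens) for cytotoxicity, read by WST assay, with a stated time of 72 h (on this read-out lower numbers stand for stronger inhibition and higher numbers for weaker inhibition), as its single number. For the measured compounds named here, compound 2 `Cc1ccc(C2(c3ccc(O)cc3)C(=O)Nc3c2ccc(F)c3F)cc1` gives 1.7 nM as the lower of the only two single numbers so far. Going by the values given here, the move between these two is a 4.2-fold lower number from compound 1 to compound 2 (0.62 log units; beyond the scatter) and it is the only measured step. Compound 3 `COc1ccc(C2(c3ccc(O)cc3)C(=O)Nc3c2ccc(F)c3F)cc1` gives 2.1 nM; 6.3 nM; > 1000 nM (3 entries) as its repeated entries in this assay. For compound 3 the last of these entries is a limit of the assay, not a number.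

Compound 4 `O=C1Nc2c(ccc(F)c2F)C1(c1ccc(O)cc1)c1ccc(F)c(F)c1` has not been measured yet. It differs from compound 2 at one place (3,4-difluorophenyl in place of 4-methylphenyl on a saturated ring carbon) where 3,4-difluorophenyl stands in place of 4-methylphenyl on a saturated ring carbon. Among the compounds with values here, the one measured step that bears on this is the arrival of the methyl, seen as a 4.2-fold lower number from compound 1 to compound 2 (0.62 log units; beyond the scatter) on that same group. Within the data shown here, compound 4 gives up this methyl and carries two fluorines that no measured step covers, so part of that gain is expected to be lost. The expected change is a 2.4-fold higher number from compound 2 to compound 4 (0.37 log units; beyond the scatter) and this is a modest rise, smaller than the measured step. The range stays wide because of the several entries of compound 3 in this assay, 2.1 nM; 6.3 nM; > 1000 nM (3 entries) whose last entry for compound 3 is a limit. The estimate for compound 4 is 4 nM with an expected range from 1.2 nM to 15 nM in this assay as the likely span.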

Compound 4, half-maximal inhibitory concentration: 7.8 nM
Compound 4: the middle estimate sits 2.0-fold (0.29 log units) below what was measured, within the range that was stated.
By their numbers in this assay, from the lowest: compound 2; then compounds 1 and 4 (each within the scatter of the next).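

At this position on a saturated ring carbon, a substituent on the phenyl ring does not by itself lower the number in this assay. Replacing phenyl with 3,4-difluorophenyl gives a 1.1-fold higher number from compound 1 to compound 4 (0.04 log units; within the scatter), so this pair cannot be told apart. Replacing 4-methylphenyl with 3,4-difluorophenyl gives a 4.6-fold higher number from compound 2 to compound 4 (0.66 log units; beyond the scatter), which means that among the three compounds with a single number, only the 4-methylphenyl group of compound 2 stands apart, while compound 4 goes against any reading that substitution on this ring helps in general.

Compound 3 cannot firmly show how a second group in the 4-position behaves, because its entries do not agree and the last of them is a limit, not a number: the several entries of compound 3 in this assay, 2.1 nM; 6.3 nM; > 1000 nM (3 entries). Still open, from the compounds shown here alone, is whether a larger group such as 4-ethylphenyl would hold the lower number seen with the methyl, how a phenyl ring carrying an amine or a carboxylic acid would behave at this carbon, and whether a single fluorine would read differently from the two in compound 4.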